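The source may report more compounds than this note shows. Statements on the series, on what has been measured and on what is new or still open speak of the compounds shown alone.

Measured compounds in the series:

- compound 1, `COc1ccc(-c2cnc(NC(=O)C3CCCCC3)n2C)cc1`
- compound 2, `CCCC(=O)Nc1ncc(-c2ccc(OC)cc2)n1C`
- compound 3, `COc1ccc(-c2cnc(NC(=O)c3ccc(C)cc3)n2C)cc1`

In a toxicity assay on THP-1 cells (Homo sapiens) for inhibition (on this read-out lower numbers stand for higher toxicity in this test and higher numbers for lower toxicity in this test), compound 1 gives > 100000 nM, which is a limit of the assay and not a number. In this assay compound 2 gives > 100000 nM, again a limit. In this assay compound 3 gives > 100000 nM, also a limit. Going by the values given here, compound 3 therefore stands at the limit of > 100000 nM in this assay, at which 3 of the 3 values shown sit, and no measured compound is set apart from it.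

The measured steps between these three are a step that the two limits leave unreadable from compound 1 to compound 2, a step that the two limits leave unreadable from compound 1 to compound 3 and a step that the two limits leave unreadable from compound 2 to compound 3. None of them gives a readable size, so the effect of changing the group on the carbonyl carbon cannot be quantified from them; what they show is only that each of the three groups leaves the compound at the limit.

Compound 4, `COc1ccc(-c2cnc(NC(=O)c3cccc(Cl)c3)n2C)cc1`, is not yet measured. It differs from compound 3 by 3-chlorophenyl in place of 4-methylphenyl on a carbonyl carbon. The bearing steps are all unreadable, so no change beyond the scatter can be derived; the expectation rests on compound 3 sitting at the limit, with compound 1 and compound 2 at the same limit.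

Compound 4 is therefore expected to remain at or near the limit in this assay, estimated at 150000 nM with a range from 40000 nM to 600000 nM. The step that this estimate means from compound 3 to compound 4 is expected to be a step that the limit leaves unreadable from compound 3 to compound 4, that is, no step beyond the scatter.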

Compound 4, half-maximal cytotoxic concentration: > 28000 nM
Compound 4: no number, only a limit; the forecaster's own chance of this, stated with the estimate: 80%; the middle value lies beyond the limit too.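

In this assay compound 4 gives > 28000 nM, which is a limit and not a number. With compound 1, compound 2 and compound 3 also at limits, none of their steps to compound 4 can be read. The compounds shown leave open whether cyclohexyl, propyl, 4-methylphenyl or 3-chlorophenyl on the carbonyl carbon differ at all in this assay.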